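A Fluorinated Amide Replaces the Thioester in Compound 4

The compounds below may be only part of what the source reports. "The series", "measured", "known", "first", "only" and "open" are said of these compounds alone.

Compound 3 `Cc1nc(S(C)(=O)=O)ccc1Oc1ncnc(OC2CCN(C(=O)SC3CC3)CC2)c1F` stands at the low end of the three numbers in a functional assay on isolated protein for inhibition of Glucose-dependent insulinotropic receptor (Rattus norvegicus), read by HTRF and cAMP accumulation (on this read-out higher numbers stand for an effect only at larger amounts of compound and lower numbers for an effect already at smaller amounts), giving 126 nM, while compound 1 `Cc1nc(S(C)(=O)=O)ccc1Oc1ncnc(OC2CCN(C(=O)OC(C)C)CC2)c1F` gives 142 nM and the step of a 1.1-fold lower number from compound 1 to compound 3 (0.05 log units; within the scatter) sits within the scatter. Compound 2 `Cc1nc(S(C)(=O)=O)ccc1Oc1ncnc(OC2CCN(C(=O)OC(C)(C)C#N)CC2)c1F` gives 1320 nM, and a 10-fold lower number from compound 2 to compound 3 (1.02 log units; beyond the scatter) is the one clear gap. Compound 4 `Cc1nc(S(C)(=O)=O)ccc1Oc1ncnc(OC2CCN(C(=O)C(C)(C)F)CC2)c1F` carries a group of 4 heavy atoms (3 carbon, 1 fluorine; no ring) in place of a group of 4 heavy atoms (3 carbon, 1 sulfur; one three-membered non-aromatic ring of carbon only), on a carbonyl carbon. Among the measured compounds shown here, two measured steps touch the same carbonyl carbon: a 1.1-fold lower number from compound 1 to compound 3 (0.05 log units; within the scatter) was within the scatter, whereas a 10-fold lower number from compound 2 to compound 3 (1.02 log units; beyond the scatter) was large; on a branched chain carbon, a 9.3-fold higher number from compound 1 to compound 2 (0.97 log units; beyond the scatter) was modest. A modest rise is therefore expected for compound 4 in this assay, estimated at 300 nM, ranging from 100 nM to 1000 nM. That expected step is a 2.4-fold higher number from compound 3 to compound 4 (0.38 log units; beyond the scatter).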

Compound 4, half-maximal effective concentration: 296 nM
Compound 4: middle estimate off by 1.0-fold (0.01 log units), on the high side; measured number inside the range.
By their numbers in this assay, from the lowest: compounds 3 and 1 (each within the scatter of the next); then compound 4; then compound 2.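

Compound 4 shows that this carbonyl carbon accepts a carbon-bound group on the amide-type nitrogen in a ring: in this assay 1-fluoro-1-methylethyl gives a 2.3-fold higher number from compound 3 to compound 4 (0.37 log units; beyond the scatter) and a 2.1-fold higher number from compound 1 to compound 4 (0.32 log units; beyond the scatter), both modest. Against 1-cyano-1-methylethoxy the same group gives a 4.5-fold lower number from compound 2 to compound 4 (0.65 log units; beyond the scatter), so it stays clear of the highest number shown. Nothing available gives a reason for these steps. On these data alone, it remains open how isopropyl without the fluorine, trifluoromethyl or cyclopropyl would read on the same carbonyl carbon.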